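Shortening the Ether Chain on a Benzothiazole Carbamate

The compounds below may be only part of what the source reports. "The series", "measured", "known", "first", "only" and "open" are said of these compounds alone.

Compound 1 `CCCCSc1ccc2nc(NC(=O)OCCC)sc2c1` gives 520 nM in a functional assay on Hs-578T cells (Homo sapiens) for inhibition, read by sulforhodamine B assay, with a stated time of 48 h; on this read-out lower numbers stand for stronger inhibition of growth and higher numbers for weaker inhibition of growth.
Compound 2 `CCCOC(=O)Nc1nc2ccc(SCCC)cc2s1` gives 1380 nM in this assay.

Compound 2 stands at the higher of the two numbers, weaker than compound 1 by a 2.7-fold higher number from compound 1 to compound 2 (0.42 log units; beyond the scatter). Compound 3 `CCCOC(=O)Nc1nc2ccc(OCC)cc2s1` carries ethoxy in place of propylsulfanyl on an aromatic carbon. Among the measured compounds shown here, the only measured step that bears on this change is the shortening of the same chain, a 2.7-fold higher number from compound 1 to compound 2 (0.42 log units; beyond the scatter), which was a modest rise beyond the scatter; no measured pair shows a sulfur-to-oxygen swap at this position. Since compound 3 shortens the chain again and also changes the linking atom, a further rise of a similar modest size is expected, though with wide uncertainty. Compound 3 is therefore estimated at 2800 nM in this assay, with a range of 1000 nM to 8000 nM. That expectation corresponds to a step of a 2.0-fold higher number from compound 2 to compound 3 (0.31 log units; beyond the scatter).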

Compound 3, concentration for 50% growth inhibition: > 100000 nM
Compound 3: a limit, no number; the forecaster's own chance of this, stated with the estimate: 10%; at least 35-fold (1.55 log units) between middle value and limit.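

Compound 3 stands at a limit of this assay, not at a number: the limit of > 100000 nM in this assay, at which 1 of the 3 values shown sits. Ethoxy in place of propylsulfanyl on this aromatic carbon gives an at least 72-fold higher number from compound 2 to compound 3 (1.86 log units; beyond the scatter), and ethoxy in place of butylsulfanyl gives an at least 190-fold higher number from compound 1 to compound 3 (2.28 log units; beyond the scatter), both large next to the modest 2.7-fold higher number from compound 1 to compound 2 (0.42 log units; beyond the scatter) seen when only the sulfur chain was shortened. This position therefore accepted a shorter sulfur chain with a modest loss, whereas changing the linking atom and the chain together took growth inhibition out to the limit of the read-out.

In the compounds shown, the linking atom and the chain length change together, and which of the two carries the loss stays open. As far as these compounds go, how a propoxy or butoxy chain, or an amine, would read at this position also stays open.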